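Cyanophenyl for cyclohexylmethyl: the next step in the series

The source may hold more compounds than are shown below. What is called first, only, known or untested is meant among the compounds shown, and "the series" means these compounds.

Of the compounds shown here, three have been measured in an in vitro functional assay on cells for agonist activity at Bombesin receptor subtype-3 (Mus musculus), read by luminescence and calcium flux; a lower number here means that less compound is needed, a higher number that more compound is needed for the effect. Compound 1 `O=C(O)c1ccccc1-c1ccc(CCc2ncc(Cc3ccccc3Cl)[nH]2)cc1` gives 22 nM, compound 2 `O=C(O)c1ccccc1-c1ccc(CCc2ncc(Cc3ccc(Cl)cc3)[nH]2)cc1` gives 102 nM, and compound 3 `O=C(O)c1ccccc1-c1ccc(CCc2ncc(CCC3CCCCC3)[nH]2)cc1` gives 33 nM. Compound 3 therefore stands second highest of the three numbers; its nearest neighbour is compound 1, with a 1.5-fold higher number from compound 1 to compound 3 (0.18 log units; within the scatter), and its furthest is compound 2, with a 3.1-fold lower number from compound 2 to compound 3 (0.49 log units; beyond the scatter). Compound 4 `N#Cc1ccccc1Cc1cnc(CCc2ccc(-c3ccccc3C(=O)O)cc2)[nH]1` differs from compound 3 by 2-cyanophenyl in place of cyclohexylmethyl on a saturated chain carbon bound to an aromatic carbon.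

Among the compounds with values here, two measured steps bear on this change, since both replace an aryl group with cyclohexylmethyl at the same place: a 1.5-fold higher number from compound 1 to compound 3 (0.18 log units; within the scatter) and a 3.1-fold lower number from compound 2 to compound 3 (0.49 log units; beyond the scatter). Going the other way, from cyclohexylmethyl back to a 2-substituted phenyl, the closer precedent is compound 1, whose step to compound 3 lies within the scatter, while a 4.6-fold higher number from compound 1 to compound 2 (0.67 log units; beyond the scatter) shows that the 4-chlorophenyl is the weaker of the two aryl tails. In this assay compound 4 is therefore expected to land close to compound 3, with a 1.3-fold lower number from compound 3 to compound 4 (0.12 log units; within the scatter). The estimate for compound 4 is 25 nM, with a range from 10 nM to 70 nM.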

Compound 4, half-maximal effective concentration: 642 nM
Compound 4: middle estimate off by 26-fold (1.41 log units), on the low side, outside the stated range (above it).
By their numbers in this assay, from the lowest: compounds 1 and 3 (each within the scatter of the next); then compound 2; then compound 4.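

In this assay, an aryl tail at this place does not reliably match cyclohexylmethyl: 2-cyanophenyl brings a large loss (a 19-fold higher number from compound 3 to compound 4 (1.29 log units; beyond the scatter)), although the 2-chlorophenyl of compound 1 and the cyclohexylmethyl of compound 3 lie within the scatter of each other. The largest contrast comes from one substituent on the same tail, cyano in place of chloro on an aromatic carbon (a 29-fold higher number from compound 1 to compound 4 (1.47 log units; beyond the scatter)), so the result for compound 1 does not extend to every 2-substituted phenyl. The 4-chlorophenyl of compound 2 is also no longer the weakest tail shown (a 6.3-fold higher number from compound 2 to compound 4 (0.80 log units; beyond the scatter)), and that place now falls to compound 4.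

Going by these compounds, whether other groups at the cyano position, such as a methoxy group, an amide or a carboxylic acid, would stay near compound 1 or fall toward compound 4 remains open. Nothing shown here accounts for the loss with the nitrile.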